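This account rests on a few compounds, and the source may have more. Where it says the series, first, only, none or still open, it means among the compounds named here.

Three compounds share one core and have been measured in a functional assay for inhibition, with Homo sapiens as the target; on this read-out higher numbers stand for weaker inhibition and lower numbers for stronger inhibition:

Compound 1, `COc1cccc(Nc2nccc(-c3ccc(C)o3)n2)c1`, gives 1500 nM.
Compound 2, `COc1cccc(Nc2nccc(-c3cccnc3)n2)c1`, gives 300 nM.
Compound 3, `COc1cccc(Nc2nccc(-c3sccc3C)n2)c1`, gives only a limit of the assay, > 24000 nM, and no number.

Compound 3 thus stands at the weak end of what has been measured: its reading sits at the limit (the limit of > 24000 nM in this assay, at which 1 of the 3 values shown sits), so only its floor is known. The steps leading to it were both large: an at least 16-fold higher number from compound 1 to compound 3 (1.20 log units; beyond the scatter) and an at least 80-fold higher number from compound 2 to compound 3 (1.90 log units; beyond the scatter).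

Compound 4, `COc1cccc(Nc2nccc(-c3ccc(C)s3)n2)c1`, is not yet measured. It differs from compound 3 by 5-methylthiophen-2-yl in place of 3-methylthiophen-2-yl on an aromatic carbon. The two groups contain the same atoms joined differently; the methyl simply sits at a different position of the same ring.

For the measured compounds named here, no measured step swaps these two groups directly, so the expectation rests on neighbours. Compound 1 carries a 5-methylfuran-2-yl group, the same methyl arrangement as the incoming group, and reaches 1500 nM. The 3-methyl arrangement of compound 3, by contrast, gives only a limit of the assay. The expected move is therefore a large drop, an at least 9.6-fold lower number from compound 3 to compound 4 (0.98 log units; beyond the scatter), though its size is uncertain since compound 3 has only a limit. Compound 4 is estimated at 2500 nM, within 600 nM to 12000 nM.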

Compound 4, half-maximal inhibitory concentration: 2300 nM
Estimate against measurement, compound 4: 1.1-fold (0.04 log units) above; the range from low to high includes it.
By their numbers in this assay, from the lowest: compound 2; then compounds 1 and 4 (each within the scatter of the next). At a limit, above all of these: compound 3.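

Moving the methyl around the same ring, with the same atoms throughout, is enough to change the reading in this assay: 5-methylthiophen-2-yl in place of 3-methylthiophen-2-yl gives an at least 10-fold lower number from compound 3 to compound 4 (1.01 log units; beyond the scatter) on this carbon of the shared core. With the methyl arrangement held the same, the sulfur ring and the oxygen ring cannot be told apart, since 5-methylthiophen-2-yl in place of 5-methylfuran-2-yl gives only a 1.5-fold higher number from compound 1 to compound 4 (0.19 log units; within the scatter), yet pyridin-3-yl keeps its lead over the new group, with a 7.7-fold higher number from compound 2 to compound 4 (0.88 log units; beyond the scatter) on going from one to the other. Going by these compounds, the true size of the methyl shift remains unknown because compound 3 reads only as a limit, so its step is a floor: the limit of > 24000 nM in this assay, at which 1 of the 4 values shown sits.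

The compounds shown leave open how a thiophen-2-yl group with no methyl at all would read, so it cannot be said whether the 3-methyl arrangement harms or the 5-methyl arrangement helps. They also leave open whether an aromatic ring is needed on this carbon at all, or whether an amine or a longer chain could take its place.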